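Swapping the Ketone Aryl Group in Compound 1

This account rests on a few compounds, and the source may have more. Where it says the series, first, only, none or still open, it means among the compounds named here.

For the measured compounds named here, compound 1 `COc1ccc(-c2cc3ccccc3nc2/C=C/C(=O)c2c(OC)cccc2OC)cc1` gives 4520 nM in a functional assay on MCF7 cells (Homo sapiens) for antiproliferative activity, read by XTT assay, with a stated time of 72 h (on this read-out higher numbers stand for weaker inhibition and lower numbers for stronger inhibition), the second highest of the three numbers measured so far. Compound 3 `COc1ccc(-c2cc3ccccc3nc2/C=C/C(=O)c2ccc([N+](=O)[O-])cc2)cc1` stands nearest with 4110 nM, and compound 2 `COc1ccc(-c2cc3ccccc3nc2/C=C/C(=O)c2ccc(N)cc2)cc1` stands furthest with 6920 nM. The steps of a 1.1-fold lower number from compound 1 to compound 3 (0.04 log units; within the scatter) and a 1.5-fold higher number from compound 1 to compound 2 (0.18 log units; within the scatter) both lie within the scatter, as does a 1.7-fold lower number from compound 2 to compound 3 (0.23 log units; within the scatter). Compound 4 `COc1ccc(-c2cc3ccccc3nc2/C=C/C(=O)c2sccc2N)cc1` differs from compound 1 by 3-aminothiophen-2-yl in place of 2,6-dimethoxyphenyl on a carbonyl carbon. The two measured steps that exchange the group on the carbonyl carbon bear on this move, and neither reaches beyond the scatter. For compound 4 the account therefore expects a 1.0-fold lower number from compound 1 to compound 4 (0.00 log units; within the scatter), a step that stays within the scatter. Compound 4 is estimated at 4500 nM, with a range from 2000 nM to 10000 nM.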

Compound 4, half-maximal inhibitory concentration: > 10000 nM
Compound 4: a limit, no number; the forecaster's own chance of this, stated with the estimate: 5%; middle value at least 2.2-fold (0.34 log units) from the limit.
By their numbers in this assay, from the lowest: compounds 3, 1 and 2 (each within the scatter of the next). At a limit, above all of these: compound 4.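

In this assay compound 4 gives a limit, not a number: the limit of > 10000 nM in this assay, at which 1 of the 4 values shown sits.

For the compounds shown here, with 3-aminothiophen-2-yl on the carbonyl carbon, this position gives steps beyond the scatter for the first time, an at least 2.2-fold higher number from compound 1 to compound 4 (0.34 log units; beyond the scatter) and an at least 2.4-fold higher number from compound 3 to compound 4 (0.38 log units; beyond the scatter). The third step, an at least 1.4-fold higher number from compound 2 to compound 4 (0.15 log units; that floor lies within the scatter), stays unresolved. The earlier exchanges at this position gave no sign that the group here could shift the read-out this far.

The compounds shown do not separate the thiophene ring from its amino group; a plain thiophen-2-yl or a pyridin-2-yl group would bear on that. From the compounds shown here alone, how far compound 4 lies past its limit also stays open.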